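The source may report more compounds than this note shows. Statements on the series, on what has been measured and on what is new or still open speak of the compounds shown alone.

Measured in a functional assay on M21 cells (Homo sapiens) for antiproliferative activity, read by sulforhodamine B assay, with a stated time of 48 h; a lower number here means a stronger inhibitor, a higher number a weaker inhibitor:
Compound 1 `Cc1cccc(NS(=O)(=O)c2ccc(N3CCNC3=O)cc2)c1` gives 69 nM
Compound 2 `Cc1ccc(NS(=O)(=O)c2ccc(N3CCNC3=O)cc2)cc1` gives 260 nM
Compound 3 `O=C1NCCN1c1ccc(S(=O)(=O)Nc2ccc(Cl)cc2)cc1` gives 90 nM

Among these three, compound 3 holds the second-highest number. Its gap to compound 1 is within the usual scatter, so the two cannot be ranked; against compound 2 the difference is real, with a 2.9-fold lower number from compound 2 to compound 3 (0.46 log units; beyond the scatter). Compound 4 `COc1ccc(NS(=O)(=O)c2ccc(N3CCNC3=O)cc2)cc1` differs from compound 3 in one place: methoxy in place of chloro on an aromatic carbon. Among the measured compounds shown here, no measured step exchanges chloro for methoxy, so the closest guide is the step that exchanged methyl for chloro at the same place, a 2.9-fold lower number from compound 2 to compound 3 (0.46 log units; beyond the scatter), which shows that a change of this one group, para to a large group, can move the number beyond the scatter. The step of a 3.8-fold higher number from compound 1 to compound 2 (0.58 log units; beyond the scatter) concerns the position of a methyl rather than its identity and bears only loosely here. On this basis a modest rise in the number is expected for compound 4, a 2.2-fold higher number from compound 3 to compound 4 (0.35 log units; beyond the scatter), with wide uncertainty. The estimated value for compound 4 in this assay is 200 nM, within a range from 70 nM to 600 nM.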

Compound 4, half-maximal inhibitory concentration: 580 nM
Compound 4: the middle estimate sits 2.9-fold (0.46 log units) below what was measured; measured number inside the range.
By their numbers in this assay, from the lowest: compounds 1 and 3 (each within the scatter of the next); then compound 2; then compound 4.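

In this assay chloro and methoxy, both para to a large group, are far apart (a 6.4-fold higher number from compound 3 to compound 4 (0.81 log units; beyond the scatter)), a wider step than any earlier one between groups at this place. Methoxy also gives a higher number than methyl (a 2.2-fold higher number from compound 2 to compound 4 (0.35 log units; beyond the scatter)), so the three groups now fall into an order beyond the scatter: chloro lowest, then methyl, then methoxy. Compound 4 is the weakest of the four, and its gap to the 3-methylphenyl compound is the widest step of the set (an 8.4-fold higher number from compound 1 to compound 4 (0.92 log units; beyond the scatter)).

No measurement shown gives a reason for this order. Still open, as far as these compounds go, are how an amine or a carboxylic acid at this place would compare, and whether methoxy would fare differently at the place held by the methyl of compound 1.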